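Ester for amide on the chromene-type series, third compound

The source may report more compounds than this note shows. Statements on the series, on what has been measured and on what is new or still open speak of the compounds shown alone.

Measured compounds:
compound 1 `COc1ccc2c(c1)OC(c1cc(OC)c(OC)c(OC)c1)C(C(=O)NC(C)(C)C)=C2`: 28400 nM
compound 2 `COc1ccc2c(c1)OC(c1cc(OC)c(OC)c(OC)c1)C(C(=O)Nc1ccccc1)=C2`: 17500 nM

Compound 1 and compound 2 share a core and differ only at the amide nitrogen. In a functional assay for inhibition of nuclear factor NF-kappa-B complex (Homo sapiens) (on this read-out lower numbers stand for stronger inhibition and higher numbers for weaker inhibition), compound 1 gives 28400 nM and compound 2 gives 17500 nM; the step of a 1.6-fold lower number from compound 1 to compound 2 (0.21 log units; within the scatter) stays within the scatter, so the two numbers are not separable. Compound 2 has the lowest of the two numbers but cannot be called the more potent one.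

Compound 3 `COc1ccc2c(c1)OC(c1cc(OC)c(OC)c(OC)c1)C(C(=O)OCCc1ccccc1)=C2` is not yet measured. Its change from compound 2 is phenethyloxy in place of anilino on a carbonyl carbon, which also reads as phenylcarbamoyl to phenethyloxycarbonyl. Within the data shown here, no measured step touches this exchange; the only step, a 1.6-fold lower number from compound 1 to compound 2 (0.21 log units; within the scatter), swaps one amide substituent for another and was within the scatter. On that basis no step beyond the scatter is expected in this assay for compound 3, with a wide range. Compound 3 is estimated at 20000 nM (from 7000 nM to 60000 nM), an expected step of a 1.1-fold higher number from compound 2 to compound 3 (0.06 log units; within the scatter).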

Compound 3, half-maximal inhibitory concentration: 16200 nM
For compound 3 the middle estimate is 1.2-fold (0.09 log units) above the measured one; measured number inside the range.
By their numbers in this assay, from the lowest: compounds 3, 2 and 1 (each within the scatter of the next).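

In this assay, the exchange of the amide for an ester at this carbonyl carbon gives a 1.1-fold lower number from compound 2 to compound 3 (0.03 log units; within the scatter), so replacing anilino with phenethyloxy, which also removes the amide hydrogen, produces no readable change. The comparison with the aliphatic amide gives the same picture, with a 1.8-fold lower number from compound 1 to compound 3 (0.24 log units; within the scatter) for phenethyloxy in place of (tert-butyl)amino, and the three compounds therefore remain inseparable on this read-out. No supporting data bear on why this exchange leaves the number within the scatter.

Since the linking atom and the chain differ together in this exchange, a phenethylamino amide would be needed to separate their contributions. As far as these compounds go, whether any group on this carbonyl carbon can move the number beyond the scatter remains open, for example a carboxylic acid or a methyl ester.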